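Replacing the 3-chlorophenyl group of compound 1

The source may hold more compounds than are shown below. What is called first, only, known or untested is meant among the compounds shown, and "the series" means these compounds.

Values so far in an ADME assay on CHO cells (Cricetulus griseus) for cytotoxicity, read by LDH release; a higher number here means a weaker inhibitor, a lower number a stronger inhibitor (lowest concentrations mark the stronger inhibitors):
compound 1 `CC(Oc1ccc(Cl)cc1Cl)C(=O)NCc1cccc(Cl)c1` gives 19000 nM
compound 2 `COc1cccc(CNC(=O)C(C)Oc2ccc(Cl)cc2Cl)c1` gives > 100000 nM (a limit of the assay)
compound 3 `CC(Oc1ccc(Cl)cc1Cl)C(=O)NCc1ccc2occc2c1` gives 11000 nM

Among the measured compounds shown here, compound 1 and compound 3 lie within the scatter of each other, so compound 1 has only one measured number to be placed against. Compound 4 `CC(Oc1ccc(Cl)cc1Cl)C(=O)NCc1ccc(F)cn1` is the next case, with the change 5-fluoropyridin-2-yl in place of 3-chlorophenyl on a saturated chain carbon bound to an amide-type nitrogen in the core of compound 1. For the measured compounds named here, only one measured step bears on it: methoxy in place of chloro, an at least 5.2-fold higher number from compound 1 to compound 2 (0.72 log units; beyond the scatter) and beyond the scatter. Going by the values given here, compound 4 also loses that chloro, so a higher number is expected, though no measured step covers the 5-fluoropyridin-2-yl group. The expected change is a 2.1-fold higher number from compound 1 to compound 4 (0.32 log units; beyond the scatter) in this assay here. Compound 4 is estimated at 40000 nM (range 12000 nM to 100000 nM).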

Compound 4, half-maximal inhibitory concentration: > 100000 nM
Compound 4 ended at the assay's limit; the forecaster's own chance of this, stated with the estimate: 30%; at least 2.5-fold (0.39 log units) between middle value and limit.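

In this assay, a change of the whole ring, 5-fluoropyridin-2-yl in place of 3-chlorophenyl, gives an at least 5.2-fold higher number from compound 1 to compound 4 (0.72 log units; beyond the scatter). This step rests on a limit of the assay, so its full size cannot be read. A second, different change at the 3-chlorophenyl group of compound 1 now ends at the same limit, and compound 2 and compound 4 cannot be ordered: the limit of > 100000 nM in this assay, at which 2 of the 4 values shown sit.

Going by these compounds, it remains open whether the ring nitrogen or the fluorine carries the step. Also open, on these data alone, is whether an amine or a carboxylic acid on this ring would give a value short of the limit.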